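Working notes: cytotoxicity of compound 3 and compound 4

The compounds below may be only part of what the source reports. "The series", "measured", "known", "first", "only" and "open" are said of these compounds alone.

Measured compounds and values in an ADME assay on L929 cells (Mus musculus) for cytotoxicity, read by resazurin assay, with a stated time of 72 h; a lower number here means a stronger inhibitor, a higher number a weaker inhibitor:
compound 1 `O=C(c1ccn(-c2ccc3c(c2)B(O)OC3)c1)c1ccc(Cl)cc1Cl`: > 10 ug/mL (a limit)
compound 2 `O=C(c1cccc(Cl)c1)c1ccn(-c2ccc3c(c2)B(O)OC3)c1`: > 10 ug/mL (a limit)
compound 3 `CCc1ccc(C(=O)c2ccn(-c3ccc4c(c3)B(O)OC4)c2)cc1`: > 10 ug/mL (a limit)

Compound 3 gives only a limit in this assay, not a number. Compound 1 gives a limit as well. Compound 2 likewise gives a limit. The steps a step that the two limits leave unreadable from compound 1 to compound 2, a step that the two limits leave unreadable from compound 1 to compound 3 and a step that the two limits leave unreadable from compound 2 to compound 3 are therefore unreadable; all three values sit at the limit of > 10 ug/mL in this assay, at which 3 of the 3 values shown sit. Compound 4 `NCc1ccc(C(=O)c2ccn(-c3ccc4c(c3)B(O)OC4)c2)cc1` differs from compound 3 by amino in place of methyl on a saturated chain carbon bound to an aromatic carbon. Among the measured compounds shown here, none of the measured steps can be sized, so no direction is expected beyond the scatter, and the step that the limit leaves unreadable from compound 3 to compound 4 is expected to be flat. Compound 4 is estimated at 15 ug/mL, range 5 ug/mL to 50 ug/mL, with a limit the likely outcome.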

Compound 4, half-maximal inhibitory concentration: > 10 ug/mL
Compound 4: no number, only a limit; the forecaster's own chance of this, stated with the estimate: 85%; the middle value does not contradict the limit.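

In this assay compound 4 gives > 10 ug/mL, a limit. Its steps from compound 1, compound 2 and compound 3 therefore cannot be read: the limit of > 10 ug/mL in this assay, at which 4 of the 4 values shown sit.

The compounds shown leave open whether any of compound 1, compound 2, compound 3 and compound 4 differ at all in this assay.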